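A few compounds are considered here, and "the series" means these few. Any claim that something is new, unique, unknown or untested is made for them only; others in the source may bear on it.

Measured so far:
compound 1 `CC(C)(N)C(=O)N[C@H](COCc1ccccc1)c1nnn(Cc2cccc(NS(C)(=O)=O)c2)n1` — > 5000 nM
compound 2 `CC(C)(N)C(=O)N[C@H](COCc1ccccc1)c1nnn(CC2Cc3ccccc3N2S(C)(=O)=O)n1` — > 5000 nM

Compound 1, `CC(C)(N)C(=O)N[C@H](COCc1ccccc1)c1nnn(Cc2cccc(NS(C)(=O)=O)c2)n1`, was tested in an assay on isolated protein for displacement of a labelled ligand from growth hormone secretagogue receptor type 1 (Homo sapiens), with a stated time of 1 h (a higher number here means a weaker inhibitor, a lower number a stronger inhibitor), where compound 1 gives > 5000 nM, a limit of the assay and not a number. Compound 2, `CC(C)(N)C(=O)N[C@H](COCc1ccccc1)c1nnn(CC2Cc3ccccc3N2S(C)(=O)=O)n1`, in this assay gives > 5000 nM, again a limit rather than a measured value. Where compound 1 stands can be said only loosely: the limit of > 5000 nM in this assay, at which 2 of the 2 values shown sit, so the numbers shown do not separate compound 1 from compound 2. The next compound, compound 3, `CC(C)(N)C(=O)N[C@H](COCc1ccccc1)c1nnn(CC#N)n1`, differs from compound 1 in one place: cyano in place of 3-(methanesulfonamido)phenyl on a saturated chain carbon bound to an aromatic nitrogen. Among the measured compounds shown here, no step between measured compounds is available to set the size of this change. Since compound 1 sits at a limit, only a move toward stronger binding could register in this assay, and nothing in the numbers shown points to one. The step from compound 1 to compound 3 is expected to be a number no higher from compound 1 to compound 3 (the limit leaves the size open), none beyond the scatter. Compound 3 is therefore expected to give about 5000 nM, with a range from 1500 nM to 20000 nM.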

Compound 3, inhibition constant: > 5000 nM
Compound 3: a limit, no number; the forecaster's own chance of this, stated with the estimate: 75%; the middle value sits exactly at the limit.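

In this assay compound 3 gives > 5000 nM, a limit of the assay and not a number. Compound 1 also sits at a limit, so the step between compound 1 and compound 3 cannot be read: the limit of > 5000 nM in this assay, at which 3 of the 3 values shown sit. The compounds shown leave open how strongly any of them binds, and whether exchanging 3-(methanesulfonamido)phenyl for cyano alters binding at all.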